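A few compounds are considered here, and "the series" means these few. Any claim that something is new, unique, unknown or untested is made for them only; others in the source may bear on it.

Compounds measured in an ADME assay on MT4 cells (Homo sapiens) for cytotoxicity, read by MTT assay, with a stated time of 4 days; a higher number here means that more compound is tolerated, a lower number that less compound is tolerated:
compound 1 `Cc1cc(-c2ccc(C#N)cc2)cc(C)c1Nc1ccnc(Nc2ccc(C#N)cc2)n1` gives 2080 nM
compound 2 `Cc1cc(-c2cccc(Cl)c2)cc(C)c1Nc1ccnc(Nc2ccc(C#N)cc2)n1` gives 2160 nM

Compound 2 and compound 1 sit within the scatter of each other in this assay, so neither is set apart. The change to compound 3 `Cc1cc(-c2ccccc2Cl)cc(C)c1Nc1ccnc(Nc2ccc(C#N)cc2)n1` is 2-chlorophenyl in place of 3-chlorophenyl on an aromatic carbon. For the measured compounds named here, the one measured step that bears on this position, a 1.0-fold higher number from compound 1 to compound 2 (0.02 log units; within the scatter), was within the scatter, and it is the only guide available. No step beyond the scatter is therefore expected in this assay for the move to compound 3. The expected step is a 1.0-fold lower number from compound 2 to compound 3 (0.01 log units; within the scatter). Compound 3 is estimated at 2100 nM, with a range of 1000 nM to 4500 nM.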

Compound 3, half-maximal cytotoxic concentration: 3990 nM
The estimate for compound 3 lay 1.9-fold (0.28 log units) below the measured number; the range from low to high includes it.
By their numbers in this assay, from the lowest: compounds 1, 2 and 3 (each within the scatter of the next).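

In this assay, for the compounds shown here, the swap of 3-chlorophenyl for 2-chlorophenyl gives a 1.8-fold higher number from compound 2 to compound 3 (0.27 log units; within the scatter) and is the first test of where the chlorine sits on this ring. Replacing 4-cyanophenyl with 2-chlorophenyl gives a 1.9-fold higher number from compound 1 to compound 3 (0.28 log units; within the scatter) as well. Going by these compounds alone, neither step leaves the scatter, so all three groups at this place read alike, with no compound set apart.

Open, going by these compounds, is whether an amine or a carboxylic acid on this ring would move the number beyond the scatter. Nothing at hand explains the numbers seen here.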